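Moving the dimethylsulfamoyl group around the phenyl ring

The source may hold more compounds than are shown below. What is called first, only, known or untested is meant among the compounds shown, and "the series" means these compounds.

Three compounds share one core, differing only in the aryl group on the tetrazole carbon. In an assay on microsomes from brain for inhibition of Fatty-acid amide hydrolase 1 (Rattus norvegicus), read by fluorescence and HPLC, with a stated time of 60 min (on this read-out higher numbers stand for weaker inhibition and lower numbers for stronger inhibition), compound 1 `CCCCCCCCc1ccc(OCC(=O)Cn2nnnc2-c2cccc(Cl)c2)cc1` gives 360 nM, compound 2 `CCCCCCCCc1ccc(OCC(=O)Cn2nnnc2-c2ccccc2Cl)cc1` gives 4600 nM and compound 3 `CCCCCCCCc1ccc(OCC(=O)Cn2nnnc2-c2ccc(S(=O)(=O)N(C)C)cc2)cc1` gives 1400 nM. Compound 3 thus holds the second highest number of the three, a 3.3-fold lower number from compound 2 to compound 3 (0.52 log units; beyond the scatter) and a 3.9-fold higher number from compound 1 to compound 3 (0.59 log units; beyond the scatter).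

Compound 4 `CCCCCCCCc1ccc(OCC(=O)Cn2nnnc2-c2cccc(S(=O)(=O)N(C)C)c2)cc1` carries 3-(dimethylsulfamoyl)phenyl in place of 4-(dimethylsulfamoyl)phenyl on an aromatic carbon. Among the measured compounds shown here, no measured pair moves a group from the 4- to the 3-position directly. The nearest evidence is indirect: a 13-fold higher number from compound 1 to compound 2 (1.11 log units; beyond the scatter) and a 3.9-fold higher number from compound 1 to compound 3 (0.59 log units; beyond the scatter), both showing that compound 1, bearing a 3-substituted phenyl, gives the lowest number seen. On that basis a modest fall in this assay is expected, a 2.0-fold lower number from compound 3 to compound 4 (0.30 log units; within the scatter), though the evidence rests on a different substituent. For compound 4 the expected value is 700 nM, with a range from 250 nM to 2000 nM.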

Compound 4, half-maximal inhibitory concentration: 1900 nM
Beside the measured number, compound 4's estimate is 2.7-fold (0.43 log units) below it; the measured number falls inside the stated range.
By their numbers in this assay, from the lowest: compound 1; then compounds 3 and 4 (each within the scatter of the next); then compound 2.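

In this assay, the 3-(dimethylsulfamoyl)phenyl and 4-(dimethylsulfamoyl)phenyl groups cannot be told apart, with a 1.4-fold higher number from compound 3 to compound 4 (0.13 log units; within the scatter) at this place on the shared core. The low number of compound 1 is therefore not a feature of any 3-substituted phenyl: dimethylsulfamoyl in place of chloro gives a 5.3-fold higher number from compound 1 to compound 4 (0.72 log units; beyond the scatter) and the change from 2-chlorophenyl gives a 2.4-fold lower number from compound 2 to compound 4 (0.38 log units; beyond the scatter) in the other direction. Nothing measured here explains these steps.

Open, from the compounds shown here alone, is whether 4-chlorophenyl would sit near the 3-chlorophenyl of compound 1 or differ from it. Also open, going by these compounds, is where 3-aminophenyl or 3-carboxyphenyl would fall.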